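This account rests on a few compounds, and the source may have more. Where it says the series, first, only, none or still open, it means among the compounds named here.

Compound 1 `N#Cc1c(-c2ccccc2O)cc(-c2ccsc2)[nH]c1=O` and compound 2 `CCOc1ccccc1-c1cc(-c2ccsc2)[nH]c(=O)c1C#N` share one core and differ in a single place: ethyl in place of hydrogen on an oxygen on an aromatic ring. In a functional assay on HT-29 cells (Homo sapiens) for cytotoxicity, with a stated time of 72 h (on this read-out lower numbers stand for stronger inhibition and higher numbers for weaker inhibition), compound 1 gives 46000 nM, while in this assay compound 2 gives 1250 nM, so that the change made a 37-fold lower number from compound 1 to compound 2 (1.57 log units; beyond the scatter). Compound 3 `N#Cc1c(-c2ccccc2O)cc(-c2ccsc2)[nH]c1=N` rests on a second core; how that core differs from the core of compound 1 is not broken down here. In this assay compound 3 gives "not determined" (no result reported), so no result is available for it there. Compound 4 `CCOc1ccccc1-c1cc(-c2ccsc2)[nH]c(=N)c1C#N` stands to compound 3 as compound 2 stands to compound 1: the change is ethyl in place of hydrogen on an oxygen on an aromatic ring, with the same place as before, so it is the same change. Since compound 3 carries no number in this assay, the step to compound 4 cannot be set beside the earlier one as a measured pair; what can be said is that the same change, seen once, went from compound 1 to compound 2 as a 37-fold lower number from compound 1 to compound 2 (1.57 log units; beyond the scatter). Compound 4 is therefore expected, on that single precedent and with wide bounds, to give about 2500 nM in this assay, plausibly between 300 nM and 20000 nM.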

Compound 4, half-maximal inhibitory concentration: 6000 nM
Beside the measured number, compound 4's estimate is 2.4-fold (0.38 log units) below it; the range from low to high includes it.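

In this assay, among the compounds shown here, compound 3 carries no number, so no step from compound 3 to compound 4 can be read. The compounds shown leave open whether hydroxy to ethoxy has the same size of effect on the core of compound 3 as on the core of compound 1. No measured evidence bears on the result for compound 4.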